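This account rests on a few compounds, and the source may have more. Where it says the series, first, only, none or still open, it means among the compounds named here.

Measured compounds in an ADME assay on BCBL1 cells (Homo sapiens) for cytotoxicity, with a stated time of 7 days; on this read-out lower numbers stand for higher toxicity in this test and higher numbers for lower toxicity in this test:
Compound 1, `CCCCCCCCOc1nc(N)nc2c1ncn2/C=C1/CC1(CO)CO`. In this assay compound 1 gives > 20000 nM, which is a limit of the assay and not a number.
Compound 2, `CCCCSc1nc(N)nc2c1ncn2/C=C1/CC1(CO)CO`. In this assay compound 2 gives > 20000 nM, likewise a limit of the assay.
Compound 3, `Nc1nc(NC2CC2)c2ncn(/C=C3/CC3(CO)CO)c2n1`. In this assay compound 3 gives 71500 nM.

For the measured compounds named here, compound 1 therefore stands only at a limit in this assay; two of the three values sit there (the limit of > 20000 nM in this assay, at which 2 of the 3 values shown sit), and the one numerical value, from compound 3, also indicates low toxicity.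

Compound 4, `CCCOc1nc(N)nc2c1ncn2/C=C1/CC1(CO)CO`, differs from compound 1 by hydrogen in place of pentyl on a saturated chain carbon, three bonds along the chain from an oxygen on an aromatic ring. Three measured steps exist in the series, all exchanging the group on the aromatic carbon: a step that the two limits leave unreadable from compound 1 to compound 2, a step that the limit leaves unreadable from compound 1 to compound 3, and a step that the limit leaves unreadable from compound 2 to compound 3. None of them shortens the chain itself, and none is readable in size, so they set no direction for the present change. What the series does show is that every variation on that carbon leaves the compound with low toxicity in this assay.

The step that the limit leaves unreadable from compound 1 to compound 4 is accordingly expected to be none beyond the scatter, with the result most likely again reported as a limit. For compound 4 the expected value is 60000 nM, estimated within 20000 nM to 200000 nM.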

Compound 4, half-maximal cytotoxic concentration: > 20000 nM
Compound 4 was reported as a limit (the forecaster's own chance of this, stated with the estimate: 70%); the middle value is on the limit's open side.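

In this assay compound 4 gives > 20000 nM, a limit of the assay and not a number, so its steps to compound 1, compound 2 and compound 3 cannot be read. Whether propoxy and octyloxy differ at all in this assay stays open, with most values at one limit: the limit of > 20000 nM in this assay, at which 3 of the 4 values shown sit.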